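The source may report more compounds than this note shows. Statements on the series, on what has been measured and on what is new or still open speak of the compounds shown alone.

Measured compounds:
compound 1 `O=C(CCCCC1CCSS1)NCc1cn(CCCCOc2ccc3cc(-c4ccc(Cl)cc4)c(=O)oc3c2)nn1` gives 74.9% in a functional assay on PC-12 cells (Rattus norvegicus) for cytotoxicity, read by MTT assay, with stated times of 3 h and 2 h, tested at 50 uM; a higher number here means a stronger effect of the compound at the concentration tested, a lower number a weaker effect;
compound 2 `O=C(CCCCC1CCSS1)NCc1cn(CCCCCOc2ccc3ccc(=O)oc3c2)nn1` gives 84.9%;
compound 3 `Cc1cc(=O)oc2cc(OCCCCCn3cc(CNC(=O)CCCCC4CCSS4)nn3)ccc12` gives 73.7%.

Compound 2 has the highest of these three numbers, though compound 1 lies within the scatter of it; only compound 3 falls beyond it, by a number 11.2 percentage points lower from compound 2 to compound 3 (beyond the scatter), a methyl in place of hydrogen on an aromatic carbon. Compound 4 `O=C(CCCCC1CCSS1)NCc1cn(CCCCCOc2ccc3cc(-c4ccc(Br)cc4)c(=O)oc3c2)nn1` differs from compound 2 by 4-bromophenyl in place of hydrogen on an aromatic carbon. Among the compounds with values here, no measured step covers such a change directly. Within the data shown here, the closest guide is compound 1, which carries a 4-chlorophenyl and reads within the scatter of compound 2, and the only step beyond the scatter, to compound 3, is modest. So in this assay compound 4 is expected to show a number 7.9 percentage points lower from compound 2 to compound 4 (within the scatter), nothing beyond the scatter. The estimate for compound 4 is 77%, within 63% to 91%.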

Compound 4, a percentage reported as activity, at one concentration (the size of the read-out at that concentration, not a potency): 53.6%
Compound 4: middle estimate off by 23.4 percentage points, on the high side; the measured number lies below the stated range.
By their numbers in this assay, from the lowest: compound 4; then compounds 3, 1 and 2 (each within the scatter of the next, the first and the last beyond it).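

Placing 4-bromophenyl on this aromatic carbon, two atoms from the ring oxygen, gives a number 31.3 percentage points lower from compound 2 to compound 4 (beyond the scatter) in this assay. This is the first step shown at this position, and it shows that a large aryl group here can substantially reduce the read-out at the concentration tested. Nothing measured here explains the drop.

A single substituent cannot separate the contribution of the phenyl ring from that of its bromine. As far as these compounds go, whether an unsubstituted phenyl or a small amine on this carbon would lower the number as far remains open.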